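Furan for Pyrrole in a Cyanoacrylamide Series

A few compounds are considered here, and "the series" means these few. Any claim that something is new, unique, unknown or untested is made for them only; others in the source may bear on it.

Measured compounds:
compound 1, `N#C/C(=C\c1c(F)c(F)c(F)c(F)c1F)C(=O)c1c[nH]c2ccccc12`, 18000 nM
compound 2, `COc1ccc(CNC(=O)/C(C#N)=C/c2ccc[nH]2)cc1`, > 50000 nM
compound 3, `N#C/C(=C\c1ccc[nH]1)C(=O)NCc1ccc(Cl)c(Cl)c1`, 85000 nM

All three were tested in a functional assay on HT-29 cells (Homo sapiens) for inhibition, read by MTT assay, with a stated time of 72 h; on this read-out lower numbers stand for stronger inhibition of growth and higher numbers for weaker inhibition of growth. Compound 1 gives 18000 nM in this assay. Compound 3 gives 85000 nM in this assay. For compound 2 the result in this assay is only a limit, > 50000 nM, and not a number; the limit is that described in the limit of > 50000 nM in this assay, at which 1 of the 3 values shown sits. So compound 2 stands at the weak end of what is shown, with no numerical value of its own, and no step between two measured compounds is available for comparison.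

Compound 4, `COc1ccc(CNC(=O)/C(C#N)=C/c2ccoc2)cc1`, differs from compound 2 in one place: furan-3-yl in place of 1H-pyrrol-2-yl on a double-bonded chain carbon bound to a double-bonded chain carbon. The pyrrole that leaves carries one hydrogen-bond donor, the furan that enters carries one hydrogen-bond acceptor and no donor. Among the compounds with values here, no measured step informs on this exchange, and compound 2 itself offers only a limit. The step from compound 2 to compound 4 is therefore expected to lie within the scatter, in no particular direction: a step that the limit leaves unreadable from compound 2 to compound 4. Compound 4 is expected to give about 60000 nM in this assay, somewhere between 20000 nM and 150000 nM, with a fair chance that the assay again reports only a limit.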

Compound 4, concentration for 50% growth inhibition: 6000 nM
Beside the measured number, compound 4's estimate is 10-fold (1.00 log units) above it, outside the stated range (below it).
By their numbers in this assay, from the lowest: compound 4; then compound 1; then compound 3.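

In this assay, furan-3-yl in place of 1H-pyrrol-2-yl on a double-bonded chain carbon bound to a double-bonded chain carbon gives an at least 8.3-fold lower number from compound 2 to compound 4 (0.92 log units; beyond the scatter). Within the data shown here, the earlier compounds offered no readable step at all, so this is the first sign that the ring at this place matters for growth inhibition, and the change lies beyond the usual scatter. Its size is a bound and not an exact difference, since compound 2 has only a limit: the limit of > 50000 nM in this assay, at which 1 of the 4 values shown sits.

The exchange removes a hydrogen-bond donor and brings in a hydrogen-bond acceptor, but it also changes the ring's hetero atom and its point of attachment, and a single step cannot separate these changes. The compounds shown leave open whether a thiophene or a furan-2-yl at the same place would match compound 4, and so which of these differences carries the step. They also leave open whether the same exchange would lower the number with the dichlorophenyl-bearing amide of compound 3, or with an amine or a carboxylic acid on the aromatic ring of the benzyl group.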